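Swapping Iodo for Nitro: What to Expect of Compound 4

This account rests on a few compounds, and the source may have more. Where it says the series, first, only, none or still open, it means among the compounds named here.

Compound 1 `CC(=NNC(=S)Nc1cccc(I)c1)c1ccccn1` was tested in a functional assay on T98G cells (Homo sapiens) for cytotoxicity, read by MTT assay, with a stated time of 48 h (on this read-out higher numbers stand for weaker inhibition and lower numbers for stronger inhibition), where compound 1 gives 61 nM. Compound 3 `C/C(=N/NC(=S)Nc1cccc(I)c1)c1ccccn1` gives 61 nM, and compound 2 `C/C(=N\NC(=S)Nc1ccc(Cl)cc1)c1ccccn1` gives 5.9 nM. Compound 1 thus stands level with compound 3 at the highest of the three numbers, with compound 2 furthest from it at a lower number beyond the scatter. Among the compounds with values here, the only measured step, no change at the digits printed from compound 1 to compound 3 (within the scatter), rests on the fact that one of compounds 1 and 3 is drawn with a defined configuration and the other without, at the place where they differ and leaves the aryl substituent untouched. Compound 4 `CC(=NNC(=S)Nc1cccc([N+](=O)[O-])c1)c1ccccn1` differs from compound 1 by nitro in place of iodo on an aromatic carbon. Within the data shown here, no measured step exchanges one substituent for another at this place, so no step beyond the scatter is expected in this assay. Compound 4 is therefore estimated at 50 nM, within 15 nM to 200 nM. The expected step is a 1.2-fold lower number from compound 1 to compound 4 (0.09 log units; within the scatter).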

Compound 4, half-maximal inhibitory concentration: 140 nM
The estimate for compound 4 lay 2.8-fold (0.45 log units) below the measured number; measured number inside the range.
By their numbers in this assay, from the lowest: compound 2; then compounds 1 and 3 (each within the scatter of the next); then compound 4.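

In this assay, nitro in place of iodo on an aromatic carbon, meta to a large group, gives a 2.3-fold higher number from compound 1 to compound 4 (0.36 log units; beyond the scatter). This shows that the number responds, if modestly, to the substituent at this place, which the earlier single step could not show, as it left the iodo group untouched. Nothing in the data shown accounts for the size or direction of this step.

From the compounds shown here alone, whether an amine, a methoxy group or a carboxylic acid at this place would leave the number level with compound 1 or move it further stays open. So does whether a defined double-bond configuration would matter with nitro as it did not with iodo.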